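This account rests on a few compounds, and the source may have more. Where it says the series, first, only, none or still open, it means among the compounds named here.

In a functional assay (uterus) for inhibition, with Rattus norvegicus as the target (on this read-out higher numbers stand for an effect only at larger amounts of compound and lower numbers for an effect already at smaller amounts), compound 1 (`Brc1cncc2nccn12`) gives 0.29 nM and compound 2 (`NC(=O)c1cn2c(Br)cncc2n1`) gives 0.41 nM. For the measured compounds named here, compound 2 therefore stands within the scatter of compound 1, and these are the only two numbers available so far.

The next structure is compound 3 (`N#Cc1cn2c(Br)cncc2n1`), with cyano in place of carbamoyl on an aromatic carbon. This carbon belongs to a five-membered aromatic ring with 2 nitrogen, part of a fused or bridged system of two rings.

Going by the values given here, only one measured step bears on this change: a 1.4-fold higher number from compound 1 to compound 2 (0.15 log units; within the scatter), with carbamoyl in place of hydrogen on the same carbon. That step lies within the scatter. Among the compounds with values here, no cyano compound has been measured, so the evidence is thin and the range has to stay wide.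

On that single step, no change beyond the scatter is expected in this assay. The expected step is a 1.2-fold lower number from compound 2 to compound 3 (0.07 log units; within the scatter). The estimated value for compound 3 is 0.35 nM, within an expected range of 0.12 nM to 1 nM.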

Compound 3, concentration for half-maximal effect: 0.78 nM
Beside the measured number, compound 3's estimate is 2.2-fold (0.35 log units) below it, and the stated range covers the measured number.
By their numbers in this assay, from the lowest: compounds 1, 2 and 3 (each within the scatter of the next, the first and the last beyond it).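

At this aromatic carbon of the five-membered ring, in this assay, cyano in place of carbamoyl gives a 1.9-fold higher number from compound 2 to compound 3 (0.28 log units; within the scatter), so the two groups cannot be told apart on this read-out. For the compounds shown here, measured against hydrogen on the same carbon, cyano gives a 2.7-fold higher number from compound 1 to compound 3 (0.43 log units; beyond the scatter), the only step among the three compounds that lies beyond the scatter, though it is modest, whereas carbamoyl gives a 1.4-fold higher number from compound 1 to compound 2 (0.15 log units; within the scatter) and stays within it; the position is therefore not wholly indifferent to what it carries, but the sensitivity seen so far rests on this single cyano step. Nothing measured here accounts for the difference between cyano and hydrogen at this carbon.

Still open, going by these compounds, is whether other groups on this carbon, such as an amine, a carboxylic acid or a longer chain, would move the number further from that of hydrogen, and in which direction. Also open, on these data alone, is whether the step from hydrogen to cyano would hold on a core carrying something other than bromine.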